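From Compound 2 to Compound 4: a Halogen Change

The compounds below may be only part of what the source reports. "The series", "measured", "known", "first", "only" and "open" are said of these compounds alone.

Three measured compounds share one core. Compound 1 `CCCc1ccc(/C=C/C(=O)Nc2ccc3nc(CCC)cc(N)c3c2)cc1` gives 4 nM in an assay on isolated protein for displacement of a labelled ligand from melanin-concentrating hormone receptor 1 (Homo sapiens); a higher number here means a weaker inhibitor, a lower number a stronger inhibitor. Compound 2 `CCCc1cc(N)c2cc(NC(=O)/C=C/c3ccc(F)cc3)ccc2n1` gives 130 nM in this assay, the second highest of the three numbers; its nearest neighbour is compound 1, and its furthest is compound 3 `CCCc1cc(N)c2cc(NC(=O)CCc3ccccc3)ccc2n1`, which gives 8300 nM. For the measured compounds named here, the one measured step that touches the aryl group, a 33-fold higher number from compound 1 to compound 2 (1.51 log units; beyond the scatter), shows that what sits on that ring can shift the number a great deal. Compound 4 `CCCc1cc(N)c2cc(NC(=O)/C=C/c3cccc(Cl)c3)ccc2n1` differs from compound 2 in this way: 3-chlorophenyl in place of 4-fluorophenyl on a double-bonded chain carbon bound to a double-bonded chain carbon. Going by the values given here, no measured pair sets a chlorine against a fluorine, or a 3-substituted ring against a 4-substituted one, so the direction of this step is open; the size of a 33-fold higher number from compound 1 to compound 2 (1.51 log units; beyond the scatter) only warns that the step could be large in either direction. Compound 4 is therefore expected near 100 nM, within a wide range from 20 nM to 500 nM. That estimate amounts to an expected 1.3-fold lower number from compound 2 to compound 4 (0.11 log units; within the scatter).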

Compound 4, half-maximal inhibitory concentration: 1100 nM
Compound 4: the middle estimate sits 11-fold (1.04 log units) below what was measured; measured number above the stated range.
By their numbers in this assay, from the lowest: compound 1; then compound 2; then compound 4; then compound 3.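

At this place on the chain, the change of aryl group has a clear direction in this assay: 3-chlorophenyl in place of 4-fluorophenyl gives an 8.5-fold higher number from compound 2 to compound 4 (0.93 log units; beyond the scatter) and so makes the inhibitor weaker. Set against the 4-propylphenyl group, the same 3-chlorophenyl group gives a 280-fold higher number from compound 1 to compound 4 (2.44 log units; beyond the scatter), so among these three aryl groups the 4-propylphenyl group gives the strongest inhibitor and the 3-chlorophenyl group the weakest. No supporting evidence accounts for either shift.

The step from compound 2 to compound 4 changes the halogen and its ring position together, so the two effects cannot be separated, and a 4-chlorophenyl or 3-fluorophenyl group would be needed to tell them apart. As far as these compounds go, whether a longer chain, such as a 4-butylphenyl group, would give a lower number than the 4-propylphenyl group also remains open.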